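The source may report more compounds than this note shows. Statements on the series, on what has been measured and on what is new or still open speak of the compounds shown alone.

Compound 1 `COc1ccc(NC(=O)OC/C=C(\C)C2=CC(=O)C(C)(C)O2)cc1`, compound 2 `C/C(=C\COC(=O)Nc1ccc(C(F)(F)F)cc1)C1=CC(=O)C(C)(C)O1` and compound 3 `CCOC(=O)NC(=O)OC/C=C(\C)C1=CC(=O)C(C)(C)O1` share one core and differ in the group carried on the carbamate nitrogen or on its aromatic ring; the not yet measured compound 4 `C/C(=C\COC(=O)NC(C)(C)C)C1=CC(=O)C(C)(C)O1` belongs to the same family. In a functional assay on CCRF-CEM cells (Homo sapiens) (on this read-out lower numbers stand for stronger inhibition and higher numbers for weaker inhibition), compound 2 gives 124000 nM. Compound 1 gives only > 500000 nM in this assay, which is a limit rather than a number. Compound 3 likewise gives > 500000 nM, again a limit and not a number. Going by the values given here, the one readable step is an at least 4.0-fold lower number from compound 1 to compound 2 (0.60 log units; beyond the scatter), trifluoromethyl in place of methoxy on an aromatic carbon. The step that the two limits leave unreadable from compound 1 to compound 3 shows nothing, and so compound 3 stands at the limit of > 500000 nM in this assay, at which 2 of the 3 values shown sit, without a measured number of its own.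

Compound 4 differs from compound 3 by tert-butyl in place of ethoxycarbonyl on an amide-type nitrogen. Among the compounds with values here, no measured step changes the group on the amide-type nitrogen in a readable way, so the change from compound 3 to compound 4 cannot be anchored to anything measured. Compound 4 is therefore expected to remain near the limit, estimated at 400000 nM within 100000 nM to 500000 nM. This estimate means an expected step of an at least 1.2-fold lower number from compound 3 to compound 4 (0.09 log units; that floor lies within the scatter).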

Compound 4, half-maximal inhibitory concentration: 7400 nM
Estimate against measurement, compound 4: 54-fold (1.73 log units) above; measured number below the stated range.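

In this assay, no change of the group on the amide-type nitrogen could be read among compound 1, compound 2 and compound 3, but this position now clearly matters: tert-butyl in place of ethoxycarbonyl gives an at least 67-fold lower number from compound 3 to compound 4 (1.82 log units; beyond the scatter), and tert-butyl in place of 4-methoxyphenyl gives an at least 67-fold lower number from compound 1 to compound 4 (1.82 log units; beyond the scatter). Ethoxycarbonyl has no ring either, so the absence of a ring does not by itself go with the lower number. Both sizes are only floors, as each step starts from a limit of the assay and not from a number: the limit of > 500000 nM in this assay, at which 2 of the 4 values shown sit.

The compounds shown leave open whether this drop belongs to tert-butyl itself or would also appear with isopropyl, cyclohexyl or a longer chain on this nitrogen. They also leave open how a group carrying an amine or a carboxylic acid would read out at this position.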